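The source may report more compounds than this note shows. Statements on the series, on what has been measured and on what is new or still open speak of the compounds shown alone.

In a functional assay on HT-1080 cells (Homo sapiens) for cytotoxicity, read by MTT assay, with a stated time of 72 h (on this read-out higher numbers stand for weaker inhibition and lower numbers for stronger inhibition), compound 1 `COc1cccc(/C=C2\CCC/C(=C\c3cccc(Br)c3)C2=O)c1OC` gives 12200 nM, and compound 2 `COc1cccc(/C=C2\CCC/C(=C\c3ccc(O)c(O)c3)C2=O)c1OC` gives 4700 nM. Compound 3 `COc1ccc(/C=C2\CCC/C(=C\c3cccc(Cl)c3)C2=O)cc1OC` gives 4900 nM, which is within the scatter of the value for compound 2 and clearly lower than the value for compound 1. The next structure, compound 4 `COc1ccc(/C=C2\CCC/C(=C\c3ccc(Br)cc3)C2=O)cc1OC`, has not yet been measured. It differs from compound 3 by 4-bromophenyl in place of 3-chlorophenyl on a double-bonded chain carbon bound to a double-bonded ring carbon, with 4-bromophenyl in place of 3-chlorophenyl on a double-bonded chain carbon bound to a double-bonded ring carbon. Among the measured compounds shown here, only one measured step changes a group at that place: a 2.6-fold lower number from compound 1 to compound 2 (0.41 log units; beyond the scatter). This modest step bears on the change only loosely, as it replaces 3-bromophenyl with 3,4-dihydroxyphenyl on a different dimethoxyphenyl arrangement. For the measured compounds named here, no measured pair exchanges one halogen-bearing phenyl for another, so no change beyond the scatter is expected in this assay. The estimated step is a 1.1-fold higher number from compound 3 to compound 4 (0.05 log units; within the scatter). Compound 4 is expected at about 5500 nM, with an estimated range of 2500 nM to 12500 nM.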

Compound 4, half-maximal inhibitory concentration: 4300 nM
Compound 4: the middle estimate sits 1.3-fold (0.11 log units) above what was measured, and the stated range covers the measured number.
By their numbers in this assay, from the lowest: compounds 4, 2 and 3 (each within the scatter of the next); then compound 1.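

In this assay, among the compounds shown here, 4-bromophenyl in place of 3-chlorophenyl on a double-bonded chain carbon bound to a double-bonded ring carbon gives a 1.1-fold lower number from compound 3 to compound 4 (0.06 log units; within the scatter), the first measured exchange of one halogen-bearing phenyl for another at this place. On the core of compound 3, this place therefore accepts the exchange without a change that can be told from the scatter. Nothing on hand explains why the two groups read alike.

The exchange alters both the halogen and its location on the phenyl, so the compounds shown do not separate the two, and opposing contributions cannot be ruled out. Also open, as far as these compounds go, is how an amine or a carboxylic acid on this phenyl, in place of the halogen, would read on the same core.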